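The compounds below may be only part of what the source reports. "The series", "measured", "known", "first", "only" and "open" are said of these compounds alone.

Values measured in an ADME assay (liver) for metabolic stability, with Liver microsome (Rattus norvegicus) as the target, using microsomes and NADPH, with a stated time of 30 min, tested at 1 uM; on this read-out higher numbers stand for fast clearance and lower numbers for slow clearance:
- Compound 1 `Cc1ccc(-c2cc(C(O)(C(F)(F)F)C(F)(F)F)cnc2N2CCN(S(=O)(=O)c3ccc(N)nc3)CC2)cn1` gives 182 mL.min-1.g-1
- Compound 2 `COc1ccc(-c2cc(C(O)(C(F)(F)F)C(F)(F)F)cnc2N2CCN(S(=O)(=O)c3ccc(N)nc3)CC2)cn1` gives 265 mL.min-1.g-1
- Compound 3 `Nc1ccc(S(=O)(=O)N2CCN(c3ncc(C(O)(C(F)(F)F)C(F)(F)F)cc3-c3ccc4sccc4c3)CC2)cn1` gives 487 mL.min-1.g-1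

The three compounds share one core and differ only in the aromatic group on it. Compounds 1 and 2 are close to each other (a 1.5-fold higher number from compound 1 to compound 2 (0.16 log units; within the scatter)). Compound 3 stands clearly apart from compound 1 (a 2.7-fold higher number from compound 1 to compound 3 (0.43 log units; beyond the scatter)), but not from compound 2 (a 1.8-fold higher number from compound 2 to compound 3 (0.26 log units; within the scatter)).

Compound 4 `Nc1ccc(S(=O)(=O)N2CCN(c3ncc(C(O)(C(F)(F)F)C(F)(F)F)cc3-c3ccc4ocnc4c3)CC2)cn1` has 1,3-benzoxazol-5-yl in place of 1-benzothiophen-5-yl on an aromatic carbon. The group that enters keeps the two-ring shape of the one that leaves, but its five-membered aromatic ring has 2 hetero atoms.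

Within the data shown here, no measured step exchanges one two-ring group for another, so the evidence is indirect. The nearest guide is the pair of steps from the pyridinyl compounds to compound 3, one modest (a 2.7-fold higher number from compound 1 to compound 3 (0.43 log units; beyond the scatter)) and one within the scatter (a 1.8-fold higher number from compound 2 to compound 3 (0.26 log units; within the scatter)). Compound 4 also carries a ring nitrogen, as compounds 1 and 2 do, so a partial move back towards them is expected. That expected move is small and stays within the scatter (a 1.6-fold lower number from compound 3 to compound 4 (0.21 log units; within the scatter)). The estimate for compound 4 is (300 mL.min-1.g-1), with an expected range from (140 mL.min-1.g-1) to (620 mL.min-1.g-1).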

Compound 4, intrinsic clearance in microsomes: 120 mL.min-1.g-1
Compound 4: middle estimate off by 2.5-fold (0.40 log units), on the high side; measured number outside the range, below it.
By their numbers in this assay, from the lowest: compounds 4, 1, 2 and 3 (each within the scatter of the next, the first and the last beyond it).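

Compound 4 shows that at this position, on an aromatic carbon ortho to a large group, the two-ring shape does not by itself fix the read-out in this assay: exchanging one two-ring group for another with the same count of heavy atoms gives a 4.1-fold lower number from compound 3 to compound 4 (0.61 log units; beyond the scatter), the largest step among these compounds. The 1,3-benzoxazol-5-yl compound also stands apart from the methoxypyridinyl compound, with a 2.2-fold lower number from compound 2 to compound 4 (0.34 log units; beyond the scatter), yet it is not separated from the methylpyridinyl compound, with a 1.5-fold lower number from compound 1 to compound 4 (0.18 log units; within the scatter), so a two-ring group here can give a number in the same range as a single-ring group. No measurement shown here accounts for the size of this step.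

The compounds shown leave open whether the step follows the loss of sulfur, the gain of oxygen or the gain of nitrogen, as all three change at once; 1,3-benzothiazol-5-yl and 1-benzofuran-5-yl groups would pull these changes apart. Also open, on these data alone, is whether the point of attachment matters, which a 1,3-benzoxazol-6-yl group would test.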